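The source may hold more compounds than are shown below. What is called first, only, known or untested is meant among the compounds shown, and "the series" means these compounds.

Values in a functional assay on SK-OV-3 cells (Homo sapiens) for cytotoxicity, read by sulforhodamine B assay; on this read-out higher numbers stand for weaker inhibition and lower numbers for stronger inhibition:
- compound 1 `CSc1ccc(N(C)c2nc(C)nc3ccccc23)cc1`: 1.6 nM
- compound 2 `CSc1ccc(N(C)c2ncnc3ccccc23)cc1`: 13.6 nM

Of these two compounds, compound 2 stands highest at 13.6 nM, so it is the weaker inhibitor here, and its nearest neighbour is compound 1 at 1.6 nM. The next compound, compound 3 `CSc1ccc(N(C)c2nc(Cl)nc3ccccc23)cc1`, keeps the shared core and carries chloro in place of hydrogen on an aromatic carbon, between two ring nitrogen atoms: chloro in place of hydrogen on an aromatic carbon.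

Among the compounds with values here, only one measured step bears on this carbon: an 8.5-fold higher number from compound 1 to compound 2 (0.93 log units; beyond the scatter). It is modest but beyond the scatter, and read backwards it shows that compound 1, with methyl on this carbon, has the lower number. Within the data shown here, no measurement yet shows what chloro does there, and one pair is thin evidence. A step in the same direction is therefore expected, toward a lower number and probably somewhat smaller than the methyl step, with wide margins.

The step expected here is a 3.4-fold lower number from compound 2 to compound 3 (0.53 log units; beyond the scatter).

For compound 3 the estimated value is 4 nM, with an expected range from 1.2 nM to 14 nM.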

Compound 3, half-maximal inhibitory concentration: 3.3 nM
Compound 3: the middle estimate sits 1.2-fold (0.08 log units) above what was measured; the range from low to high includes it.
By their numbers in this assay, from the lowest: compound 1; then compound 3; then compound 2.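

In this assay, chloro on this carbon, between two ring nitrogen atoms, also gives a lower number than hydrogen (a 4.1-fold lower number from compound 2 to compound 3 (0.62 log units; beyond the scatter)), so the effect seen on replacing hydrogen here is not confined to methyl. Chloro does not fully match methyl, however, and the direct comparison of the two groups lies beyond the scatter (a 2.1-fold higher number from compound 1 to compound 3 (0.31 log units; beyond the scatter)), placing methyl lowest and hydrogen highest among the three compounds. No available evidence accounts for this order.

On these data alone, what stays open is whether the order extends to other groups on this carbon, such as an amine, a methoxy group, or a longer alkyl chain, and whether any of them would give a lower number than methyl. Also open, as far as these compounds go, is whether the same order would hold if the shared core were changed elsewhere, since all three compounds keep the rest of the structure unchanged and the comparison rests on this single cell assay.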